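Trimming a methoxy from the aryl ketone of compound 3

The compounds below may be only part of what the source reports. "The series", "measured", "known", "first", "only" and "open" are said of these compounds alone.

Three chalcone-like compounds built on a shared core have been measured in a functional assay on OVCAR-5 cells (Homo sapiens) for cytotoxicity, read by sulforhodamine B assay, with a stated time of 48 h, tested at 10 uM; on this read-out higher numbers stand for a weaker effect at the one concentration tested and lower numbers for a stronger effect. Compound 1 `COc1cc(-c2cc(/C=C/C(=O)c3ccc(N)cc3)[nH]n2)cc(OC)c1OC` gives -66%, compound 2 `COc1cc(-c2cc(/C=C/C(=O)c3ccc(Cl)c(Cl)c3)[nH]n2)cc(OC)c1OC` gives 65%, and compound 3 `COc1ccc(C(=O)/C=C/c2cc(-c3cc(OC)c(OC)c(OC)c3)n[nH]2)cc1OC` gives -93%. Compound 3 therefore stands lowest of the three, meaning the strongest effect at the tested concentration; the step of a number 27 percentage points lower from compound 1 to compound 3 (beyond the scatter) is modest, while a number 158 percentage points lower from compound 2 to compound 3 (beyond the scatter) is large, as is a number 131 percentage points higher from compound 1 to compound 2 (beyond the scatter).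

The next compound, compound 4 `COc1ccc(C(=O)/C=C/c2cc(-c3cc(OC)c(OC)c(OC)c3)n[nH]2)cc1`, differs from compound 3 by hydrogen in place of methoxy on an aromatic carbon. Every measured step also changed the aryl group on the carbonyl carbon, so they bear on this change only in showing that this part of the molecule matters a great deal in this assay. The closest comparison is the modest step from compound 1 to compound 3, where a 4-aminophenyl became a 3,4-dimethoxyphenyl; taking one methoxy away again is a smaller alteration than that. Compound 3 already sits near the strongest readings seen here, so there is little room for the number to fall further.

Compound 4 is therefore expected to show a small step toward a weaker effect, a number 18 percentage points higher from compound 3 to compound 4 (beyond the scatter), staying within or just beyond the scatter. The estimate for compound 4 is -75%, with a range from -100% to -30%.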

Compound 4, a percentage reported as activity, at one concentration (the size of the read-out at that concentration, not a potency): -70%
For compound 4 the middle estimate is 5 percentage points below the measured one, within the range that was stated.
By their numbers in this assay, from the lowest: compound 3; then compounds 4 and 1 (each within the scatter of the next); then compound 2.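

In this assay, among these compounds, taking away this one methoxy, so that 3,4-dimethoxyphenyl becomes 4-methoxyphenyl, gives a number 23 percentage points higher from compound 3 to compound 4 (beyond the scatter) and isolates a single group, whereas the earlier steps replaced the substituents on the aryl ketone in larger changes. Two further comparisons place the new compound among the others: there is a number 135 percentage points lower from compound 2 to compound 4 (beyond the scatter) for the change from 3,4-dichlorophenyl, a far larger step than losing the methoxy, and a number 4 percentage points lower from compound 1 to compound 4 (within the scatter) for methoxy in place of amino, so these two groups cannot be told apart on this read-out. Among the compounds shown here, nothing available explains why the single methoxy shifts the number by this amount.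

The compounds shown leave open whether a hydroxy group, a fluorine or an ethoxy group at the place of the lost methoxy would restore the number seen with compound 3, and what a plain phenyl ketone with no substituent would give. Every number comes from one concentration, so the compounds also leave open whether the groups would show a stronger or weaker effect relative to one another at other concentrations.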